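Removing the fluorine from compound 3 in the search for cytotoxicity

The compounds below may be only part of what the source reports. "The series", "measured", "known", "first", "only" and "open" are said of these compounds alone.

Among the compounds with values here, compound 3 `COc1cc(-c2cc(COCc3cn(Cc4cc(-c5ccc(F)cc5)cnc4Cl)nn3)on2)cc(OC)c1OC` gives the lowest of the three numbers so far in a functional assay on MCF7 cells (Homo sapiens) for cytotoxicity, read by MTT assay, with a stated time of 48 h (a higher number here means a weaker inhibitor, a lower number a stronger inhibitor), at 76400 nM, though this lies within the scatter of compound 1 `COc1cc(COCc2cn(Cc3cc(-c4ccccc4)cnc3Cl)nn2)cc(OC)c1OC`, which gives 86700 nM, and of compound 2 `COc1cc(COCc2cn(Cc3cc(-c4ccc(F)cc4)cnc3Cl)nn2)cc(OC)c1OC`, which gives 96600 nM. Compound 4 `COc1cc(-c2cc(COCc3cn(Cc4cc(-c5ccccc5)cnc4Cl)nn3)on2)cc(OC)c1OC` has not yet been measured; it differs from compound 3 by hydrogen in place of fluoro on an aromatic carbon. Within the data shown here, the only measured step that bears on this is the one between compound 1 and compound 2, where fluoro in place of hydrogen on an aromatic carbon gave a 1.1-fold higher number from compound 1 to compound 2 (0.05 log units; within the scatter). Reversing that change on the core shared by compound 3 and compound 4 is therefore expected to produce no step beyond the scatter in this assay, with at most a slightly lower number. Compound 4 is estimated to give 70000 nM in this assay, with a likely range from 35000 nM to 140000 nM, which means an expected step of a 1.1-fold lower number from compound 3 to compound 4 (0.04 log units; within the scatter).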

Compound 4, half-maximal inhibitory concentration: 68500 nM
Beside the measured number, compound 4's estimate is 1.0-fold (0.01 log units) above it; measured number inside the range.
By their numbers in this assay, from the lowest: compounds 4, 3, 1 and 2 (each within the scatter of the next).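

The change from 4-fluorophenyl to phenyl gives a 1.1-fold lower number from compound 3 to compound 4 (0.05 log units; within the scatter) in this assay, so the fluoro on this aromatic carbon leaves no readable mark on the number on a second core as well. Within the data shown here, earlier, this change could be read on only one core, and a single step within the scatter could not show whether the result held elsewhere. Hydrogen and fluoro at this place now give matching results on both cores: the same change on two cores in this assay, a 1.1-fold higher number (0.05 log units; within the scatter) from compound 1 to compound 2 and a 1.1-fold higher number (0.05 log units; within the scatter) from compound 4 to compound 3, 1.0-fold (0.00 log units) apart, within the scatter of two such steps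

The compounds shown leave open whether any other group at this place, para to a large group, such as an amine or a carboxylic acid, would move the number beyond the scatter. They also leave open whether such a group would behave alike on both cores.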